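Lengthening the Acid Side Chain of Compound 2

The source may report more compounds than this note shows. Statements on the series, on what has been measured and on what is new or still open speak of the compounds shown alone.

In a toxicity assay on B16-F10 cells (Mus musculus) for cytotoxicity, read by CCK-8 assay, with stated times of 16 h and 24 h (a lower number here means a stronger inhibitor, a higher number a weaker inhibitor), compound 1 `COc1ccc(C2=[N+]3C(=Nc4c(-c5ccccc5)c5c(n4[B-]3(F)F)-c3ccc(OCC(=O)O)cc3CC5)C(c3ccccc3)=C2I)cc1` gives 104 nM and compound 2 `COc1ccc(C2=[N+]3C(=Nc4c(-c5ccccc5)c5c(n4[B-]3(F)F)-c3ccc(OCC(=O)N[C@@H](CC(=O)O)C(=O)O)cc3CC5)C(c3ccccc3)=C2I)cc1` gives 65 nM so these two numbers lie within the scatter of each other. Compound 3 `COc1ccc(C2=[N+]3C(=Nc4c(-c5ccccc5)c5c(n4[B-]3(F)F)-c3ccc(OCC(=O)N[C@@H](CCC(=O)O)C(=O)O)cc3CC5)C(c3ccccc3)=C2I)cc1` departs from compound 2 by carboxymethyl in place of carboxy on a saturated chain carbon, two bonds along the chain from an amide-type nitrogen and a carbonyl carbon with carboxymethyl in place of carboxy on a saturated chain carbon. Going by the values given here, only one measured step bears on this: a 1.6-fold lower number from compound 1 to compound 2 (0.20 log units; within the scatter) when (1,2-dicarboxyethyl)amino replaces hydroxy on a carbonyl carbon. In this assay the expected change is a 1.1-fold higher number from compound 2 to compound 3 (0.03 log units; within the scatter) and so none beyond the scatter in either direction. Compound 3 is estimated at 70 nM with an expected range of 30 nM to 160 nM for repeated measurements.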

Compound 3, half-maximal inhibitory concentration: 159 nM
Beside the measured number, compound 3's estimate is 2.3-fold (0.36 log units) below it; the range from low to high includes it.
By their numbers in this assay, from the lowest: compounds 2, 1 and 3 (each within the scatter of the next, the first and the last beyond it).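

In this assay, carboxymethyl in place of carboxy on a saturated chain carbon gives a 2.4-fold higher number from compound 2 to compound 3 (0.39 log units; beyond the scatter) and so shows that this position responds to one added carbon, a modest step beyond the scatter. Measured against hydroxy on the carbonyl carbon, the (1,3-dicarboxypropyl)amino group gives a 1.5-fold higher number from compound 1 to compound 3 (0.18 log units; within the scatter) and so does not separate from it. Nothing measured here explains why the added carbon changes the number. Still open, on these data alone, is how a longer chain such as 3-carboxypropyl, or an amine in place of the carboxy, would read at this position.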